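A few compounds are considered here, and "the series" means these few. Any claim that something is new, unique, unknown or untested is made for them only; others in the source may bear on it.

Compound 1 `C=C(C)CCOC(=O)C[C@@H]1C(C(=O)OC)=CO[C@@H](O[C@@H]2O[C@H](CO)[C@@H](O)[C@H](O)[C@H]2O)/C1=C/C` is the reference point of this short series. In a functional assay on SK-BR-3 cells (Homo sapiens) for antiproliferative activity, read by MTT assay, with a stated time of 72 h (on this read-out lower numbers stand for stronger inhibition and higher numbers for weaker inhibition), compound 1 gives > 15000 nM, which is a limit of the assay and not a measured number. Compound 2 `C=C(C)CCOC(=O)C[C@@H]1C(C(=O)OC)=CO[C@@H](O[C@@H]2O[C@H](COC(C)=O)[C@@H](OC(C)=O)[C@H](OC(C)=O)[C@H]2OC(C)=O)/C1=C/C` sits in the same position: in this assay compound 2 gives > 15000 nM, again a limit rather than a value. Within the data shown here, compound 1 therefore stands at the limit of > 15000 nM in this assay, at which 2 of the 2 values shown sit, so nothing within the measured pair can be ordered or compared, and no step between measured compounds exists to lean on.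

Compound 3 `C/C=C1/[C@H](O[C@@H]2O[C@H](CO)[C@@H](O)[C@H](O)[C@H]2O)OC=C(C(=O)OC)[C@H]1CC(=O)OCCc1ccc(OC)cc1` has not yet been measured. It differs from compound 1 by 4-methoxyphenyl in place of 1-methylethenyl on a saturated chain carbon, two bonds along the chain from an oxygen next to a carbonyl group. Among the measured compounds shown here, no measured pair carries a change of this kind, so no step size can be read off for it; the only anchor is the limit at which compound 1 sits. On that anchor, the expected step in this assay is a number no higher from compound 1 to compound 3 (the limit leaves the size open), that is, none beyond the scatter. Compound 3 is accordingly expected to come out near 15000 nM in this assay, within a range from 5000 nM to 45000 nM, and most probably to be reported once more as a limit rather than a number.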

Compound 3, half-maximal inhibitory concentration: > 20000 nM
Compound 3 ended at the assay's limit (the forecaster's own chance of this, stated with the estimate: 75%); at least 1.3-fold (0.12 log units) between middle value and limit.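

In this assay compound 3 gives > 20000 nM, which is a limit and not a number. Compound 1 gives > 15000 nM, also a limit. Among these compounds, no step from compound 1 to compound 3 can be read from these two limits. The compounds shown leave open whether 4-methoxyphenyl in place of 1-methylethenyl changes antiproliferative activity at all.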